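Acetyl to Propanoyl on the Core of Compound 2

The source may report more compounds than this note shows. Statements on the series, on what has been measured and on what is new or still open speak of the compounds shown alone.

Compound 2 `CCCS(=O)(=O)N1CCN(C(C)=O)C1` carries an acetyl group on its core. Among the measured compounds shown here, in a functional assay on the whole organism with Mus musculus as the target (a higher number here means that more compound is needed for the effect, a lower number that less compound is needed), compound 2 gives 10 mg/kg, the highest of the three numbers known so far, so of these it needs the most compound for the effect. Compound 3 `CCC(=O)N1CCN(S(=O)(=O)c2ccc(F)cc2)C1` is its nearest neighbour in this set; in this assay compound 3 gives 1 mg/kg. Compound 1 `CCC(=O)N1CCCN(C(=O)c2ccccc2)CC1` stands furthest away; in this assay compound 1 gives 0.1 mg/kg. Both compounds differ from compound 2 in more than one place, so nothing beyond what their two values show can be read from them. Compound 4 `CCCS(=O)(=O)N1CCN(C(=O)CC)C1` differs from compound 2 in a single place: methyl in place of hydrogen on a saturated chain carbon bound to a carbonyl carbon. Compound 4 thus carries the propanoyl group also present in compound 1 and compound 3, while the rest of compound 2 is kept. For the measured compounds named here, no measured step of this kind is available. The expected step, estimated as a 3.3-fold lower number from compound 2 to compound 4 (0.52 log units; beyond the scatter), is toward a lower number, modest but beyond the scatter. For compound 4 in this assay the estimated value is 3 mg/kg, within a range from 1 mg/kg to 10 mg/kg.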

Compound 4, minimum effective dose: > 10 mg/kg
Compound 4 ended at the assay's limit; the forecaster's own chance of this, stated with the estimate: 5%; middle value at least 3.3-fold (0.52 log units) from the limit.
By their numbers in this assay, from the lowest: compound 1; then compound 3; then compound 2.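

Among the compounds shown here, the first measured step at this place gives a number no lower from compound 2 to compound 4 (the limit leaves the size open). Methyl in place of hydrogen on the saturated chain carbon bound to a carbonyl carbon, turning acetyl into propanoyl, therefore brings no lower number in this assay on the frame of compound 2, so the propanoyl group alone does not secure one there. Compound 4 gives > 10 mg/kg, which is a limit of the assay and not a number, and it is the only such value so far: the limit of > 10 mg/kg in this assay, at which 1 of the 4 values shown sits.

From the compounds shown here alone, how far compound 4 really lies from compound 2 stays open, and the size of the step cannot be read. Also open, going by these compounds, is how a longer chain, or an amine on this same chain carbon, would fare in place of the added methyl.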